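Trimming a Methyl from the Side Chain of Compound 3

The compounds below may be only part of what the source reports. "The series", "measured", "known", "first", "only" and "open" are said of these compounds alone.

In an ADME assay on a cell-free system (plasma, Homo sapiens) for protein binding, using equilibrium dialysis, with a stated time of 5 h, tested at 10 uM (on this read-out lower numbers stand for a smaller free fraction and higher numbers for a larger free fraction), compound 3 (`Cc1cn([C@H]2CCCN([C@@H](CC(C)C)c3ccc(C(=O)O)c(Oc4cccc(Cl)c4)c3F)C2)c(=O)[nH]c1=O`) gives 0.007. Compound 1 (`CC[C@@H](c1ccc(C(=O)O)c(Oc2cccc(Cl)c2)c1F)N1CCC[C@H](n2cc(C)c(=O)[nH]c2=O)C1`) gives 0.011, within the scatter of that number, while compound 2 (`CCC[C@@H](c1ccc(C(=O)O)c(Oc2cccc(Cl)c2)c1OC)N1CCC[C@H](n2cc(C)c(=O)[nH]c2=O)C1`) gives 0.065, well beyond it. Compound 4 (`CCC[C@@H](c1ccc(C(=O)O)c(Oc2cccc(Cl)c2)c1F)N1CCC[C@H](n2cc(C)c(=O)[nH]c2=O)C1`) is still unmeasured. It differs from compound 3 by hydrogen in place of methyl on a saturated chain carbon bound to two saturated chain carbons, which turns isobutyl into propyl. Going by the values given here, the one measured step that bears on this is another change in the same chain, a 1.6-fold lower number from compound 1 to compound 3 (0.20 log units; within the scatter). The step expected here is therefore also small, a 1.3-fold higher number from compound 3 to compound 4 (0.11 log units; within the scatter), with nothing expected beyond the scatter. Compound 4 is estimated at 0.009, with a range from 0.005 to 0.017.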

Compound 4, unbound fraction in the plasma assay: 0.007
Compound 4: middle estimate off by 1.3-fold (0.11 log units), on the high side; measured number inside the range.
By their numbers in the plasma assay, from the lowest: compounds 3, 4 and 1 (each within the scatter of the next); then compound 2.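

In the plasma assay compound 3 gives 0.007 and compound 4 gives 0.007, so the methyl removed here leaves the number unmoved, with no change at the digits printed from compound 3 to compound 4 (within the scatter), and adding a methyl to the shorter chain gives a 1.6-fold lower number from compound 1 to compound 4 (0.20 log units; within the scatter), so compounds 1, 3 and 4 show this chain tolerating these small edits. Going by these compounds alone, in the plasma assay the single swap of fluoro for methoxy on the aromatic carbon gives a 9.3-fold lower number from compound 2 to compound 4 (0.97 log units; beyond the scatter), a larger step than any seen in the chain. In a physicochemical assay for lipophilicity, using the shake flask method, in phosphate buffer, measured as octanol-water partition, at pH 7.4 (on this read-out lower numbers stand for lower lipophilicity and higher numbers for higher lipophilicity), compound 3 gives 0.57 and compound 4 gives 0.51, and removing the methyl gives a number 0.06 log units lower from compound 3 to compound 4 (within the scatter).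

From the compounds shown here alone, whether a hydroxyl group, an amine or a longer chain at this position would shift the free fraction remains open. Nothing available explains why these steps are large or small.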